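Biphenyl amide triazoles: carboxylic acid moved round the ring

This account rests on a few compounds, and the source may have more. Where it says the series, first, only, none or still open, it means among the compounds named here.

Measured so far:
Compound 1, `O=C(NCCCCCCCn1cc(-c2ccc[n+]([O-])c2)nn1)c1ccccc1-c1ccccc1`: in an assay for inhibition of Nicotinamide phosphoribosyltransferase (Mus musculus), read by fluorescence, with a stated time of 1 h, in the presence of a further agent that is not named here (on this read-out higher numbers stand for weaker inhibition and lower numbers for stronger inhibition), compound 1 gives > 500 nM, which is a limit of the assay and not a number.
Compound 2, `O=C(O)c1ccccc1-c1ccccc1C(=O)NCCCCCCCn1cc(-c2cccnc2)nn1`: in this assay compound 2 gives 38.5 nM.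
Compound 3, `NC(=O)c1ccccc1-c1ccccc1C(=O)NCCCCCCCn1cc(-c2cccnc2)nn1`: in this assay compound 3 gives 87.9 nM.

Compound 3 stands at the highest of the two numbers shown. Its nearest neighbour is compound 2, and the step of a 2.3-fold higher number from compound 2 to compound 3 (0.36 log units; beyond the scatter) lies beyond the scatter. The remaining entry is the limit (the limit of > 500 nM in this assay, at which 1 of the 3 values shown sits), and it gives no number to rank against.

Compound 4, `O=C(O)c1cccc(-c2ccccc2C(=O)NCCCCCCCn2cc(-c3cccnc3)nn2)c1`, differs from compound 3 by 3-carboxyphenyl in place of 2-carbamoylphenyl on an aromatic carbon. Two things move at once: the amide reverts to a carboxylic acid, and that acid no longer sits where the amide did. Among the measured compounds shown here, only one measured step bears on this, the exchange of carboxylic acid for carboxamide at the same place, which gave a modest rise; the shift of the group to the 3-position has no measured counterpart in this set. The acid is therefore expected to recover part of that step, while the change of place adds uncertainty in either direction.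

Compound 4 is expected to give 60 nM in this assay, within a range of 20 nM to 200 nM. That estimate means an expected step of a 1.5-fold lower number from compound 3 to compound 4 (0.17 log units; within the scatter), a small gain that may not clear the scatter.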

Compound 4, half-maximal inhibitory concentration: > 500 nM
Compound 4: only a limit was reported; the forecaster's own chance of this, stated with the estimate: 10%; at least 8.3-fold (0.92 log units) between middle value and limit.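

In this assay, keeping the carboxylic acid but carrying it as 3-carboxyphenyl in place of 2-carboxyphenyl gives an at least 12-fold higher number from compound 2 to compound 4 (1.11 log units; beyond the scatter), so the place of the acid on this ring matters, which compounds 2 and 3 could not show because they share one place. The change from 2-carbamoylphenyl to 3-carboxyphenyl gives an at least 5.6-fold higher number from compound 3 to compound 4 (0.75 log units; beyond the scatter), a larger step than the exchange of acid for amide at the same place, a 2.3-fold higher number from compound 2 to compound 3 (0.36 log units; beyond the scatter), so within these compounds the place of the group weighs more than the choice between acid and amide. Compound 4 is reported only as a limit, which is not a number, so the full size of the loss stays unknown, and it cannot be ranked against compound 1: the limit of > 500 nM in this assay, at which 2 of the 4 values shown sit.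

Still open, as far as these compounds go, is whether a tetrazole or a methyl ester in place of the carboxylic acid would keep the level of compound 2 on this ring. Also open, from the compounds shown here alone, is whether a carboxamide carried as the 3-substituted counterpart of compound 3 would follow compound 4, and whether a shorter chain to the triazole would change how much the place of the acid counts.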